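This account rests on a few compounds, and the source may have more. Where it says the series, first, only, none or still open, it means among the compounds named here.

Measured so far in a functional assay on MGC-803 cells (Homo sapiens) for antiproliferative activity, read by MTT assay, with a stated time of 72 h; on this read-out higher numbers stand for weaker inhibition and lower numbers for stronger inhibition:
- compound 1 `CCCSc1nc(N/N=C(\C)c2ccccc2O)c2nnn(Cc3ccccc3Cl)c2n1`: 35000 nM
- compound 2 `CCCSc1nc(N/N=C(\C)c2ccccc2O)c2nnn(Cc3ccccc3)c2n1`: 2310 nM
- compound 3 `CCCSc1nc(N/N=C(\C)c2ccccc2O)c2nnn(Cc3ccc(Br)cc3)c2n1`: 11300 nM

All three share one core and differ only in the group sitting on the saturated chain carbon bound to an aromatic nitrogen. Among these numbers compound 3 stands second highest. Its nearest neighbour is compound 1, the gap being a 3.1-fold lower number from compound 1 to compound 3 (0.49 log units; beyond the scatter); its furthest is compound 2, the gap being a 4.9-fold higher number from compound 2 to compound 3 (0.69 log units; beyond the scatter). The lowest number of the set belongs to compound 2, whose phenyl carries no halogen, as seen in a 15-fold lower number from compound 1 to compound 2 (1.18 log units; beyond the scatter).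

Compound 4 `CCCSc1nc(N/N=C(\C)c2ccccc2O)c2nnn(Cc3ccco3)c2n1` differs from compound 3 in a single place: furan-2-yl in place of 4-bromophenyl on a saturated chain carbon bound to an aromatic nitrogen. Going by the values given here, no measured pair exchanges the whole six-membered ring for a five-membered one, so the comparison rests on the two steps that touch compound 3, each of modest size, and on the observation that a ring without a halogen gives the lowest number. On that ground a modestly lower number is expected for compound 4 in this assay, the expected shift being a 2.5-fold lower number from compound 3 to compound 4 (0.40 log units; beyond the scatter). Compound 4 is therefore estimated at 4500 nM, with a plausible range from 1200 nM to 17000 nM.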

Compound 4, half-maximal inhibitory concentration: 4760 nM
Beside the measured number, compound 4's estimate is 1.1-fold (0.02 log units) below it; the measured number falls inside the stated range.
By their numbers in this assay, from the lowest: compound 2; then compound 4; then compound 3; then compound 1.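

In this assay, swapping a halogen-bearing ring for furan-2-yl at this place, on a saturated chain carbon bound to an aromatic nitrogen, gives a lower number in both available comparisons: a 2.4-fold lower number from compound 3 to compound 4 (0.38 log units; beyond the scatter) and a 7.4-fold lower number from compound 1 to compound 4 (0.87 log units; beyond the scatter). So a smaller, five-membered ring with an oxygen in it can stand here and still give a lower number than either halogen-bearing six-membered ring. Losing the halogen is not the whole story, however: compound 4 has no halogen either, yet the ring change from plain phenyl gives a 2.1-fold higher number from compound 2 to compound 4 (0.31 log units; beyond the scatter), so the identity of the ring also counts, and compound 2 keeps the lowest number of the four.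

No measurement shown here explains why the rings fall in this order. From the compounds shown here alone, it also remains open how this order would extend to a thiophene or pyridine ring, or to a plain butyl chain carrying no ring at all, and whether a furan-2-yl bearing a bromo group would move the number as bromo does on the phenyl of compound 3.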